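This account rests on a few compounds, and the source may have more. Where it says the series, first, only, none or still open, it means among the compounds named here.

Working notes on the series in an ADME assay on Vero cells (Chlorocebus sabaeus) for cytotoxicity, read by MTT assay, with a stated time of 72 h; a lower number here means that less compound is tolerated, a higher number that more compound is tolerated. Compound 1 `COC(=O)c1cc(-c2cccc(NC(=O)c3ccc(C4OC4C(=O)c4ccc(Cl)cc4)cc3)c2)on1` returns only a limit in this assay, > 20 ug/mL. Compound 2 `COC(=O)c1cc(-c2cccc(NC(=O)c3ccc(/C=C/C(=O)c4ccc(Cl)cc4Cl)cc3)c2)on1` likewise returns only a limit in this assay, > 40 ug/mL. Compound 3 `CCOC(=O)c1nnn(-c2cccc(NC(=O)c3ccc(/C=C/C(=O)c4ccc(Cl)cc4)cc3)c2)c1C` has no result in this assay, "not determined" (no result reported). Among the measured compounds shown here, the single step between measured neighbours, a step that the two limits leave unreadable from compound 1 to compound 2, is left unreadable by the two limits the limit of > 20 ug/mL in this assay, at which 1 of the 3 values shown sits, and (the limit of > 40 ug/mL in this assay, at which 1 of the 3 values shown sits), so compound 2 stands at a limit with no readable step beside it and no number to compare against.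

Compound 4 `COC(=O)c1cc(-c2cccc(NC(=O)c3ccc(/C=C/C(=O)c4ccc([N+](=O)[O-])cc4)cc3)c2)on1` differs from compound 2 in one place: 4-nitrophenyl in place of 2,4-dichlorophenyl on a carbonyl carbon. For the measured compounds named here, no measured step in this assay bears on this change, and the only step on record is of unreadable size, so nothing points to a direction. For compound 4 the expectation is a result at or near the limit of this assay rather than a readable number, an estimated step of a number no higher from compound 2 to compound 4 (the limit leaves the size open). The estimate for compound 4 is 40 ug/mL, with a range from 20 ug/mL to 80 ug/mL.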

Compound 4, half-maximal cytotoxic concentration: > 20 ug/mL
Compound 4: no number, only a limit; the forecaster's own chance of this, stated with the estimate: 75%; the middle value lies beyond the limit too.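

Compound 2 and compound 4 both return only limits in this assay, so no step can be read between them. The compounds shown leave open where the half-maximal cytotoxic concentration of any of them lies, and whether 4-nitrophenyl in place of 2,4-dichlorophenyl shifts it at all.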